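A Bromobenzyl Sulfide on the Shared Core

The source may hold more compounds than are shown below. What is called first, only, known or untested is meant among the compounds shown, and "the series" means these compounds.

Compound 1 `Cc1cc(N2CC[C@@H](C)[C@@H](N(C)c3ncnc4[nH]ccc34)C2)n2ncnc2n1` gives 4350 nM in a functional assay on MGC-803 cells (Homo sapiens) for inhibition, read by MTT assay, with a stated time of 72 h; a higher number here means a weaker inhibitor, a lower number a stronger inhibitor.
Compound 2 `Cc1cc(N2CC[C@@H](C)[C@@H](N(C)c3ncnc4[nH]ccc34)C2)n2nc(SCC3CC3)nc2n1` gives 9540 nM in this assay.
Compound 3 `C=CCSc1nc2nc(C)cc(N3CC[C@@H](C)[C@@H](N(C)c4ncnc5[nH]ccc45)C3)n2n1` gives 32600 nM in this assay.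

Compound 3 stands highest of the three numbers: a 7.5-fold higher number from compound 1 to compound 3 (0.87 log units; beyond the scatter) and a 3.4-fold higher number from compound 2 to compound 3 (0.53 log units; beyond the scatter) are both beyond the scatter. Compound 4 `Cc1cc(N2CC[C@@H](C)[C@@H](N(C)c3ncnc4[nH]ccc34)C2)n2nc(SCc3ccc(Br)cc3)nc2n1` differs from compound 3 by 4-bromophenyl in place of vinyl on a saturated chain carbon bound to a sulfur. The step that bears most directly is a 3.4-fold higher number from compound 2 to compound 3 (0.53 log units; beyond the scatter), where a swap on the same chain carbon bound to sulfur moved the number beyond the scatter; a 2.2-fold higher number from compound 1 to compound 2 (0.34 log units; beyond the scatter) and a 7.5-fold higher number from compound 1 to compound 3 (0.87 log units; beyond the scatter) show that each sulfanyl group so far raised the number. The entering group carries a ring where the leaving one had none, and the record is too thin to say whether this helps. A modest step downward toward compound 2 is expected, with wide uncertainty. Compound 4 is therefore estimated at 18000 nM, between 5000 nM and 60000 nM, which means an expected 1.8-fold lower number from compound 3 to compound 4 (0.26 log units; within the scatter).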

Compound 4, half-maximal inhibitory concentration: 4020 nM
The estimate for compound 4 lay 4.5-fold (0.65 log units) above the measured number; the measured number lies below the stated range.
By their numbers in this assay, from the lowest: compounds 4 and 1 (each within the scatter of the next); then compound 2; then compound 3.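

At this chain carbon bound to a sulfur, 4-bromophenyl gives an 8.1-fold lower number from compound 3 to compound 4 (0.91 log units; beyond the scatter) and a 2.4-fold lower number from compound 2 to compound 4 (0.38 log units; beyond the scatter) in this assay so the choice of group here can lower the number as well as raise it. The earlier (cyclopropylmethyl)sulfanyl and allylsulfanyl groups both raised the number over the hydrogen of compound 1, but (4-bromobenzyl)sulfanyl gives a 1.1-fold lower number from compound 1 to compound 4 (0.03 log units; within the scatter) and so does not follow them. Nothing measured here explains these differences. As far as these compounds go, whether the bromine or the aromatic ring matters stays open, as does what a plain benzyl or a 4-methoxybenzyl group would give.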